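Sulfonyl for Naphthoyl: Cytotoxicity Held at the Limit

The source may report more compounds than this note shows. Statements on the series, on what has been measured and on what is new or still open speak of the compounds shown alone.

Compound 3 `O=C(NC(=S)N1CCc2c(OCCCCCOc3ccc(Cl)cc3)cccc21)c1ccc2ccccc2c1` in an ADME assay on Huh-7 cells (Homo sapiens) for cytotoxicity (a lower number here means that less compound is tolerated, a higher number that more compound is tolerated), gives > 50000 nM, which is a limit of the assay rather than a number. Compound 1 `N#Cc1ccc(C(=O)NC(=S)N2CCc3c(OCCCCCOc4ccc(Cl)cc4)cccc32)cc1` in this assay gives > 50000 nM, again a limit. Compound 2 `O=C(NC(=S)N1CCc2c(OCCCCCOc3ccc(Cl)cc3)cccc21)C1CCCCC1` in this assay gives > 50000 nM, likewise a limit. The measured steps a step that the two limits leave unreadable from compound 1 to compound 2, a step that the two limits leave unreadable from compound 1 to compound 3 and a step that the two limits leave unreadable from compound 2 to compound 3 therefore carry no readable size, because of the limit of > 50000 nM in this assay, at which 3 of the 3 values shown sit. Compound 4 `O=S(=O)(NC(=S)N1CCc2c(OCCCCCOc3ccc(Cl)cc3)cccc21)c1ccccc1` differs from compound 3 by phenylsulfonyl in place of (naphthalen-2-yl)carbonyl on an amide-type nitrogen. Since every shown value sits at the same limit, no step beyond the scatter is expected, and a further limit is the likeliest outcome. Compound 4 is therefore estimated at 60000 nM, spanning 30000 nM to 150000 nM, which corresponds to an expected step that the limit leaves unreadable from compound 3 to compound 4.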

Compound 4, half-maximal cytotoxic concentration: > 50000 nM
Compound 4: only a limit was reported; the forecaster's own chance of this, stated with the estimate: 85%; the middle value lies beyond the limit too.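

No step from compound 1, compound 2 or compound 3 to compound 4 can be read in this assay: the limit of > 50000 nM in this assay, at which 4 of the 4 values shown sit.

The compounds shown leave open whether phenylsulfonyl and the three carbonyl groups differ at all in this assay.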